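Compound 2 loses its side chain

A few compounds are considered here, and "the series" means these few. Any claim that something is new, unique, unknown or untested is made for them only; others in the source may bear on it.

Going by the values given here, in a functional assay on A549 cells (Homo sapiens) for antiproliferative activity, read by MTT assay, with a stated time of 96 h (on this read-out lower numbers stand for stronger inhibition and higher numbers for weaker inhibition), compound 2 `NCCCCCCC(=S)N/N=C1\CC2(CCCCC2)Oc2c1ccc1ccccc21` gives 3240 nM and holds the lower of the two numbers so far, while compound 1 `S=C(CN1CCCCC1)N/N=C1\CC2(CCCCC2)Oc2c1ccc1ccccc21` gives 10600 nM and sits higher. Compound 3 `N/N=C1\CC2(CCCCC2)Oc2c1ccc1ccccc21` carries a hydrogen atom in place of a group of 9 heavy atoms (7 carbon, 1 nitrogen, 1 sulfur; no ring), on an amine nitrogen and so keeps none of that chain. Among the compounds with values here, the only measured step that bears on this is a 3.3-fold lower number from compound 1 to compound 2 (0.51 log units; beyond the scatter) and it exchanged piperidin-1-yl for 5-aminopentyl rather than removing the whole group. That modest step is weak evidence, yet a higher number of similar or larger size is expected. The estimated change is a 3.7-fold higher number from compound 2 to compound 3 (0.57 log units; beyond the scatter) in this assay overall. Compound 3 is expected at 12000 nM within an estimated range of 3500 nM to 40000 nM here.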

Compound 3, half-maximal inhibitory concentration: 12900 nM
Estimate against measurement, compound 3: 1.1-fold (0.03 log units) below, and the stated range covers the measured number.
By their numbers in this assay, from the lowest: compound 2; then compounds 1 and 3 (each within the scatter of the next).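

In this assay, taking the whole group off the amine nitrogen gives a 4.0-fold higher number from compound 2 to compound 3 (0.60 log units; beyond the scatter) and so shows that the chain carrying 5-aminopentyl counts for something at this position. The chain carrying piperidin-1-yl does not show this, since replacing it with a hydrogen atom gives a 1.2-fold higher number from compound 1 to compound 3 (0.09 log units; within the scatter) and leaves the two apart by no more than the scatter. No measurement shown here explains why the two chains differ. On these data alone, whether a longer or shorter chain in place of 5-aminopentyl would move the number remains open, as does the effect of a carboxylic acid in place of its amine.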